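Thiophene exchange on the core of compound 1

The source may hold more compounds than are shown below. What is called first, only, known or untested is meant among the compounds shown, and "the series" means these compounds.

Among the measured compounds shown here, compound 1 `N=C(N)N/N=C/c1c(-c2cc(Cl)sc2Cl)nc2n1CCS2` gives 1820 nM in a functional assay on cells (Cancer cell lines, Homo sapiens) for inhibition (a lower number here means a stronger inhibitor of growth, a higher number a weaker inhibitor of growth), the lowest of the three numbers so far. Compound 2 `N=C(N)N/N=C/c1c(-c2ccsc2)nc2sccn12` stands at 14100 nM and compound 3 `Cc1cc(-c2nc3sccn3c2/C=N/NC(=N)N)c(C)s1` at 15500 nM. Compound 4 `N=C(N)N/N=C/c1c(-c2cccs2)nc2n1CCS2` is still unmeasured. It differs from compound 1 as follows: thiophen-2-yl in place of 2,5-dichlorothiophen-3-yl on an aromatic carbon.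

For the measured compounds named here, only one measured step touches the thiophene: a 1.1-fold higher number from compound 2 to compound 3 (0.04 log units; within the scatter), within the scatter. It involves thiophen-3-yl and 2,5-dimethylthiophen-3-yl on a different core, so it bears on this change only loosely. Compound 2 and compound 3 carry no chlorine and both stand higher than compound 1, but their core differs as well, and the data cannot separate the two changes. Going by the values given here, no measured pair on the core of compound 1 exists. A moderate move towards a higher number is therefore expected, with wide uncertainty.

The estimated step is a 2.2-fold higher number from compound 1 to compound 4 (0.34 log units; beyond the scatter). Compound 4 is expected at 4000 nM, with an estimated range of 1200 nM to 13000 nM.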

Compound 4, concentration for 50% growth inhibition: 17400 nM
For compound 4 the middle estimate is 4.4-fold (0.64 log units) below the measured one; the whole stated range lies below it.
By their numbers in this assay, from the lowest: compound 1; then compounds 2, 3 and 4 (each within the scatter of the next).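

On the core of compound 1, in this assay, thiophen-2-yl in place of 2,5-dichlorothiophen-3-yl gives a 9.6-fold higher number from compound 1 to compound 4 (0.98 log units; beyond the scatter). Among the compounds shown here, this is the first measured change at this aromatic carbon on this core, and unlike the one earlier thiophene step, which lay within the scatter, it shows that the group at this position can move the growth-inhibition number beyond the scatter. Nothing on hand accounts for the size of this step.

As far as these compounds go, this single step removes both chlorine atoms and moves the thiophene attachment from its 3-position to its 2-position, so the share of each remains open. Also open, from the compounds shown here alone, is how this position on the shared core responds to a non-thiophene group such as phenyl or a longer alkyl chain.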